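Changing the Fused Ring Group of Compound 2

This account rests on a few compounds, and the source may have more. Where it says the series, first, only, none or still open, it means among the compounds named here.

In a functional assay on NCI-N87 cells (Homo sapiens) for inhibition, read by CellTiter-Glo, with a stated time of 72 h (a higher number here means a weaker inhibitor, a lower number a stronger inhibitor), compound 1 `Cc1cc(Nc2ncnc3cc(O)c(NC(=O)/C=C/[C@H]4CCCN4C)cc23)ccc1Oc1cc2nccn2cn1` gives 41.7 nM, while compound 2 `Cc1cc(Nc2ncnc3cc(O)c(NC(=O)/C=C/[C@H]4CCCN4C)cc23)ccc1Oc1ccc2nccn2c1` gives 4.08 nM, the lower and therefore stronger of the two numbers. These compounds share a core and differ only in the fused ring group on an oxygen on an aromatic ring. Compound 3 `Cc1cc(Nc2ncnc3cc(O)c(NC(=O)/C=C/[C@H]4CCCN4C)cc23)ccc1Oc1ccn2cnnc2c1` keeps that core and changes the same place: a group of 9 heavy atoms (6 carbon, 3 nitrogen; one five-membered aromatic ring with 3 hetero atoms, one six-membered aromatic ring with 1 hetero atom) in place of a group of 9 heavy atoms (7 carbon, 2 nitrogen; one five-membered aromatic ring with 2 hetero atoms, one six-membered aromatic ring with 1 hetero atom), on an oxygen on an aromatic ring. Going by the values given here, only one measured step bears on this change: a 10-fold lower number from compound 1 to compound 2 (1.01 log units; beyond the scatter), which is large and beyond the scatter. In that step, a nitrogen-richer group gave way to a carbon-richer one, whereas compound 3 goes the opposite way. However, its group differs from that of compound 1, and one step is thin evidence. A smaller rise in this assay is therefore expected, a 2.5-fold higher number from compound 2 to compound 3 (0.39 log units; beyond the scatter). The estimate for compound 3 is 10 nM, within a range of 3 nM to 35 nM.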

Compound 3, half-maximal inhibitory concentration: 32.9 nM
Compound 3: the middle estimate sits 3.3-fold (0.52 log units) below what was measured; measured number inside the range.
By their numbers in this assay, from the lowest: compound 2; then compounds 3 and 1 (each within the scatter of the next).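

The second step shows that the low number of compound 2 depends on the exact group on this oxygen: keeping the two rings and exchanging one ring carbon for nitrogen gives an 8.1-fold higher number from compound 2 to compound 3 (0.91 log units; beyond the scatter) in this assay. The two groups of 6 carbon and 3 nitrogen differ in how their nitrogens are shared between the rings, yet they show a 1.3-fold lower number from compound 1 to compound 3 (0.10 log units; within the scatter), so this arrangement makes no measurable difference here, and in these three compounds only the group of 7 carbon and 2 nitrogen gives the lower number. Nothing measured here explains this loss of activity. On these data alone, whether a methyl group or an amine on the group of compound 2 would keep its low number remains open. So does whether a group with fewer ring nitrogens would lower the number further.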